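From 4-methoxyphenyl to thiophen-2-yl on the shared core

A few compounds are considered here, and "the series" means these few. Any claim that something is new, unique, unknown or untested is made for them only; others in the source may bear on it.

Among the compounds with values here, in a functional assay on CCRF-CEM cells (Homo sapiens) for antiproliferative activity (a higher number here means a weaker inhibitor, a lower number a stronger inhibitor), compound 2 (`COc1ccc(-c2cc(N)c(C(=O)c3cc(OC)c(OC)c(OC)c3)s2)cc1`) gives 19 nM, the higher of the two numbers so far, while compound 1 (`COc1cc(C(=O)c2sc(-c3cccc([N+](=O)[O-])c3)cc2N)cc(OC)c1OC`) gives 5.9 nM. Compound 3 (`COc1cc(C(=O)c2sc(-c3cccs3)cc2N)cc(OC)c1OC`) carries thiophen-2-yl in place of 4-methoxyphenyl on an aromatic carbon. Within the data shown here, the only measured step at this place is a 3.2-fold higher number from compound 1 to compound 2 (0.51 log units; beyond the scatter), a modest one. With so little evidence, only a small move toward a lower number, not clearly beyond the scatter, is expected: a 1.6-fold lower number from compound 2 to compound 3 (0.20 log units; within the scatter). Compound 3 is estimated at 12 nM, with an expected range of 4 nM to 40 nM.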

Compound 3, half-maximal inhibitory concentration: 9.4 nM
Beside the measured number, compound 3's estimate is 1.3-fold (0.11 log units) above it; the measured number falls inside the stated range.
By their numbers in this assay, from the lowest: compounds 1 and 3 (each within the scatter of the next); then compound 2.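

In this assay, the place on the aromatic carbon next to the ring sulfur accepts a five-membered aromatic ring as well as the six-membered ones seen before: thiophen-2-yl in place of 4-methoxyphenyl gives a 2.0-fold lower number from compound 2 to compound 3 (0.31 log units; beyond the scatter), a modest step. Thiophen-2-yl in place of 3-nitrophenyl gives a 1.6-fold higher number from compound 1 to compound 3 (0.20 log units; within the scatter), so these two groups cannot be told apart here, although thiophen-2-yl is the smaller ring.

From the compounds shown here alone, whether an amine or a carboxylic acid at this place would keep such numbers stays open. Nothing shown here accounts for the differences among these groups.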